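Ester Variation at the Aromatic Hydroxyl: Series Notes

A few compounds are considered here, and "the series" means these few. Any claim that something is new, unique, unknown or untested is made for them only; others in the source may bear on it.

Measured so far in a functional assay on HL-60 cells (Homo sapiens) for cytotoxicity, read by MTT assay, with a stated time of 24 h; a lower number here means a stronger inhibitor, a higher number a weaker inhibitor:
compound 1 `COC(=O)/C(=C\c1ccc(O)cc1)Sc1ccnc2cc(Cl)ccc12`: 4310 nM
compound 2 `COC(=O)/C(=C\c1ccc(OC(=O)c2c(OC)cccc2OC)cc1)Sc1ccnc2cc(Cl)ccc12`: 37200 nM
compound 3 `COC(=O)/C(=C\c1ccc(OC(=O)c2cc(OCc3ccccc3)c(OCc3ccccc3)c(OCc3ccccc3)c2)cc1)Sc1ccnc2cc(Cl)ccc12`: no number, only a limit, > 100000 nM

Among the compounds with values here, compound 2 stands at the highest of the two numbers reported; the only measured step in this set is an 8.6-fold higher number from compound 1 to compound 2 (0.94 log units; beyond the scatter), so attaching an aryl ester to the hydroxyl weakens the compound. For compound 3 the reading is a limit, namely (the limit of > 100000 nM in this assay, at which 1 of the 3 values shown sits), and it tells no more than that the ester with three benzyloxy groups sits at or beyond the weak end.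

Compound 4 `COC(=O)/C(=C\c1ccc(OC(=O)c2ccc(OC)c(OC)c2OC)cc1)Sc1ccnc2cc(Cl)ccc12` differs from compound 2 by 2,3,4-trimethoxyphenyl in place of 2,6-dimethoxyphenyl on a carbonyl carbon. Within the data shown here, no measured step compares two different aryl esters with each other, so the step from compound 1 to compound 2 is the only one that bears on compound 4, and it is already built into compound 2. Compound 4 keeps the ester, so a number near that of compound 2 is expected, with the limit of compound 3 leaving room for a somewhat higher value; the expected step is a 1.2-fold higher number from compound 2 to compound 4 (0.08 log units; within the scatter). Compound 4 is therefore estimated at 45000 nM, with a range from 15000 nM to 120000 nM.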

Compound 4, half-maximal inhibitory concentration: 2080 nM
Compound 4: middle estimate off by 22-fold (1.34 log units), on the high side; measured number outside the range, below it.
By their numbers in this assay, from the lowest: compound 4; then compound 1; then compound 2. At a limit, above all of these: compound 3.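

In this assay the outcome at this oxygen depends heavily on the aryl group carried by the ester: with the ester kept and 2,3,4-trimethoxyphenyl in place of 2,6-dimethoxyphenyl on the carbonyl carbon, the series shows an 18-fold lower number from compound 2 to compound 4 (1.25 log units; beyond the scatter) and this is a large step for a change confined to the aryl group. Ester formation at the hydroxyl therefore does not weaken the compound in every case: compound 1 with the free hydroxyl gives 4310 nM and compound 4 gives 2080 nM so the weakening seen with compound 2 holds for that ester alone, and compound 4 goes against it as a general pattern. Nothing measured in this set accounts for the difference between the two aryl groups.

Compounds 2 and 4 differ both in the number of methoxy groups and in their arrangement on the ring, so the set leaves open which of the two matters. Also open, going by these compounds, is how a plain phenyl or a simple acetyl group on this oxygen would read, and whether an amide or an ether linkage in place of the ester would keep the number of compound 4.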